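The source may hold more compounds than are shown below. What is called first, only, known or untested is meant among the compounds shown, and "the series" means these compounds.

Compound 1 `OCc1cn(Cc2cccc(F)c2)c2ccccc12` and compound 2 `OCc1cn(Cc2cccc(Cl)c2)c2ccccc12` share a core that carries a hydroxymethyl group; compound 3 `OCc1cn(Cc2ccc(Cl)cc2)c2ccc(F)cc12` has a different core, and the difference between the two cores is not broken down here. In an ADME assay on T29 cells (Homo sapiens) for cytotoxicity, read by sulforhodamine B assay, with a stated time of 3 days (on this read-out higher numbers stand for weaker inhibition and lower numbers for stronger inhibition), compound 1 gives only a limit of the assay, > 31600 nM. Compound 2 likewise reaches only a limit in this assay, > 31600 nM. Among the measured compounds shown here, compound 3 gives 8120 nM in this assay, the only number among the three. The step that the two limits leave unreadable from compound 1 to compound 2 cannot be read because of the limit of > 31600 nM in this assay, at which 2 of the 3 values shown sit. The change chloro in place of fluoro on an aromatic carbon is the same kind of change as chloro in place of fluoro on an aromatic carbon, which yields compound 4 `OCc1cn(Cc2ccc(Cl)cc2)c2ccc(Cl)cc12`; it differs in its place, which in compound 4 is part of a fused or bridged system of two rings, meta to a fused ring and para to a fused ring, rather than meta to a large group. Since the earlier step gives no readable size, compound 4 is expected to stay close to compound 3, a step of a 1.0-fold lower number from compound 3 to compound 4 (0.01 log units; within the scatter), with an estimated value of 8000 nM, between 3000 nM and 25000 nM.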

Compound 4, half-maximal inhibitory concentration: > 31600 nM
Compound 4 was reported as a limit (the forecaster's own chance of this, stated with the estimate: 15%); middle value at least 3.9-fold (0.59 log units) away from the limit.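

In this assay, chloro in place of fluoro on an aromatic carbon of the core of compound 3 gives an at least 3.8-fold higher number from compound 3 to compound 4 (0.59 log units; beyond the scatter), so on this core the change weakens inhibition beyond the usual scatter. As far as these compounds go, compound 4 gives only a limit of the assay, > 31600 nM, so the full size of this step remains unknown. The same kind of change at a different place, from compound 1 to compound 2, cannot be read, so the data do not show whether its effect carries from one core to the other: the limit of > 31600 nM in this assay, at which 3 of the 4 values shown sit.

The compounds shown leave open whether a group other than fluoro or chloro at this place on the fused system, such as a methoxy group or an amine, would keep or strengthen inhibition. They also leave open how this assay would respond if the hydroxymethyl group gave way to a carboxylic acid or a longer chain.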